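The source may hold more compounds than are shown below. What is called first, only, known or untested is meant among the compounds shown, and "the series" means these compounds.

Of the compounds shown here, two have been measured in a functional assay on BXPC-3 cells (Homo sapiens) for inhibition, read by MTT assay, with a stated time of 7 days; on this read-out lower numbers stand for stronger inhibition and higher numbers for weaker inhibition. Compound 1, `CCN(CC)S(=O)(=O)c1ccc(S(=O)(=O)N2CCC[C@@H](C(=O)N3CCC(O)CC3)C2)cc1`, gives 4710 nM in this assay, the higher of the two numbers recorded. Compound 2, `CCC(CC)S(=O)(=O)c1ccc(S(=O)(=O)N2CCC[C@@H](C(=O)N3CCC(F)(F)CC3)C2)cc1`, gives 40 nM in this assay, a number far lower than that of compound 1, well beyond the scatter; as the two structures differ in more than one place, the pair shows only that such a gap exists, not what produces it. Compound 3, `CCN(CC)S(=O)(=O)c1ccc(S(=O)(=O)N2CCC[C@@H](C(=O)N3CCC(COC)CC3)C2)cc1`, is not yet measured. It differs from compound 1 in one place, (methoxymethyl in place of hydroxy on a saturated ring carbon), methoxymethyl in place of hydroxy on a saturated ring carbon. Within the data shown here, no single-change step between measured compounds covers this replacement. For compound 3 a modest step downward is expected, a 3.1-fold lower number from compound 1 to compound 3 (0.50 log units; beyond the scatter), though a result within the scatter of compound 1 would not surprise. Compound 3 is thus estimated at 1500 nM in this assay, with a range from 400 nM to 6000 nM.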

Compound 3, half-maximal inhibitory concentration: 1360 nM
Compound 3: middle estimate off by 1.1-fold (0.04 log units), on the high side, and the stated range covers the measured number.
By their numbers in this assay, from the lowest: compound 2; then compound 3; then compound 1.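

On the saturated ring carbon three ring bonds from the ring nitrogen, this assay shows that the hydroxy group is not needed for activity: replacing it with methoxymethyl gives a 3.5-fold lower number from compound 1 to compound 3 (0.54 log units; beyond the scatter). The swap removes the single hydrogen-bond donor, keeps one hydrogen-bond acceptor and adds two heavy atoms, so this ring carbon accepts a larger group without a donor and the number still falls. This one step changes all of these features at once and cannot assign the shift to any one of them, and no available evidence bears on the cause of this step. Hydroxymethyl or methoxy at this carbon could help separate the loss of the donor from the longer chain. As far as these compounds go, how an amine or a carboxylic acid would fare here also remains open.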